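Glycinate esters on a coumarin core: nitro to chloro

The compounds below may be only part of what the source reports. "The series", "measured", "known", "first", "only" and "open" are said of these compounds alone.

Measured:
compound 1 `COc1ccccc1NCC(=O)Oc1ccc2c(C)cc(=O)oc2c1` — 10.7%
compound 2 `Cc1cc(=O)oc2cc(OC(=O)CNc3ccccc3[N+](=O)[O-])ccc12` — 21.4%

In a functional assay on the whole organism (strain Wistar albino) for inhibition, with Rattus norvegicus as the target, read by paw edema, with stated times of 30 min and 1 h, at a dose of 20 mg/kg by the oral route (on this read-out lower numbers stand for less inhibition and higher numbers for more inhibition at the one dose given (going by the name of the read-out)), compound 2 stands highest of the two values, above compound 1 by a number 10.7 percentage points higher from compound 1 to compound 2 (beyond the scatter). Compound 3 `Cc1cc(=O)oc2cc(OC(=O)CNc3ccccc3Cl)ccc12` is not yet measured; it differs from compound 2 in one place: chloro in place of nitro on an aromatic carbon. Among the compounds with values here, the only measured step concerns a different exchange at the same carbon, so no step bears on it directly. The expected change is a number 5.4 percentage points lower from compound 2 to compound 3 (within the scatter), a reduction toward compound 1 but uncertain in size. Compound 3 is therefore estimated at 16% in this assay, within 8% to 26%.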

Compound 3, a percentage reported as inhibition, in the whole organism at one dose (the size of the read-out at that dose, not a potency): 21.4%
Compound 3: middle estimate off by 5.4 percentage points, on the low side; low and high end bracket the measured number.
By their numbers in this assay, from the lowest: compound 1; then compounds 2 and 3 (each within the scatter of the next).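

In this assay, the exchange of nitro for chloro on this aromatic carbon, ortho to a large group, gives no change at the digits printed from compound 2 to compound 3 (within the scatter) and so does not separate the two groups, although chloro brings one heavy atom and no hydrogen-bond acceptors where nitro brings three and two. Chloro also departs from methoxy, with a number 10.7 percentage points higher from compound 1 to compound 3 (beyond the scatter) matching the earlier step from methoxy to nitro. No measurement available here accounts for this result.

Open, from the compounds shown here alone, is whether an amine, a methyl or a carboxylic acid on this carbon would read like chloro and nitro or like methoxy. Also open, going by these compounds, is whether chloro gives the same reading on other carbons of this ring.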